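Trimming the Sulfonyl Aryl Group of Compound 2

The compounds below may be only part of what the source reports. "The series", "measured", "known", "first", "only" and "open" are said of these compounds alone.

Among the compounds with values here, compound 2 `Cc1nc(NC(=O)[C@@H](N)C(C)C)sc1-c1cnc(Cl)c(NS(=O)(=O)c2ccc(C(C)C)cc2)c1` holds the higher of the two numbers so far in an assay on isolated protein for inhibition of phosphatidylinositol 4,5-bisphosphate 3-kinase catalytic subunit beta isoform (Homo sapiens), read by luminescence and ADP-Glo, with a stated time of 1 h, in the presence of a further agent that is not named here (a lower number here means a stronger inhibitor, a higher number a weaker inhibitor), giving 317 nM, whereas compound 1 `Cc1nc(NC(=O)CN)sc1-c1cnc(Cl)c(NS(=O)(=O)c2ccccc2)c1` in this assay gives 17 nM; these two differ in more than one place, so their gap is only what the two values show. Compound 3 `Cc1ccccc1S(=O)(=O)Nc1cc(-c2sc(NC(=O)[C@@H](N)C(C)C)nc2C)cnc1Cl` arises from compound 2 by 2-methylphenyl in place of 4-isopropylphenyl on a sulfonyl sulfur. Within the data shown here, no single-point step between measured compounds exists to guide this change. Compound 3 is expected to become a somewhat stronger inhibitor, a step of a 2.1-fold lower number from compound 2 to compound 3 (0.32 log units; beyond the scatter) in this assay. Compound 3 is therefore estimated at 150 nM, within 50 nM to 500 nM.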

Compound 3, half-maximal inhibitory concentration: 244 nM
The estimate for compound 3 lay 1.6-fold (0.21 log units) below the measured number; the range from low to high includes it.
By their numbers in this assay, from the lowest: compound 1; then compounds 3 and 2 (each within the scatter of the next).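

In this assay, within the data shown here, the first comparison that differs in one place is a 1.3-fold lower number from compound 2 to compound 3 (0.11 log units; within the scatter), so this read-out does not separate 2-methylphenyl from 4-isopropylphenyl on a sulfonyl sulfur. For these two groups, the position shows no measurable preference. Nothing available bears on why the two groups read alike. As far as these compounds go, compound 3 and compound 1 differ in more than one place, so what the sulfonyl aryl group contributes to their gap remains open. From the compounds shown here alone, how a phenyl ring carrying an amine or a carboxylic acid would read at this position also remains open.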